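A few compounds are considered here, and "the series" means these few. Any claim that something is new, unique, unknown or untested is made for them only; others in the source may bear on it.

Compound 1 `Cc1cc(C(=O)Nc2cccc(F)c2)nn1Cc1cc(Cl)ccc1OCc1ccccc1` is the starting point of this step. In a physicochemical assay for lipophilicity, at pH 7.4 (a lower number here means a more polar compound, a higher number a more lipophilic compound), compound 1 gives 2.8, the lowest of the two numbers measured outright. Compound 3 `Cc1cc(NC(=O)OCc2ccccn2)nn1Cc1cc(Cl)ccc1OCc1ccccc1` carries a carbamate instead of the amide; in this assay compound 3 gives 3.1, so the step of a number 0.30 log units higher from compound 1 to compound 3 (within the scatter) stays within the scatter. Compound 2 `Cc1cc(NC(=O)C2CCOCC2)nn1Cc1cc(Cl)ccc1OCc1ccccc1` is known only through a limit of this assay, where compound 2 gives > 3.7 (the limit of > 3.7 in this assay, at which 1 of the 3 values shown sits). Measured against that limit, the step of a number at least 0.90 log units higher from compound 1 to compound 2 (beyond the scatter) is real, and the step of a number at least 0.60 log units lower from compound 2 to compound 3 (beyond the scatter) runs the other way.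

Compound 4 `CCOC(=O)Nc1cc(C)n(Cc2cc(Cl)ccc2OCc2ccccc2)n1` differs from compound 1 in one place: (ethoxycarbonyl)amino in place of (3-fluorophenyl)carbamoyl on an aromatic carbon. Going by the values given here, the closest precedent is the step to compound 3, where a carbamate also replaced the same carbamoyl group and the change stayed within the scatter; the step to compound 2 shows that exchanging this group can move the number well upward, but that step put an oxan-4-yl group on the carbonyl, not an alkoxy group. For compound 4 a step of a number 0.20 log units higher from compound 1 to compound 4 (within the scatter) is therefore expected, small and close to the scatter. Compound 4 is estimated to give 3 in this assay, expected to fall between 2.4 and 3.6.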

Compound 4, distribution coefficient: > 3.7
Compound 4 gave a limit, no number; the forecaster's own chance of this, stated with the estimate: 10%; middle value at least 0.70 log units from the limit.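

Within the carbamates, methyl in place of pyridin-2-yl on the chain gives a number at least 0.60 log units higher from compound 3 to compound 4 (beyond the scatter). The (ethoxycarbonyl)amino group in place of (3-fluorophenyl)carbamoyl gives a number at least 0.90 log units higher from compound 1 to compound 4 (beyond the scatter), so among the compounds shown, a carbamate on this aromatic carbon does not by itself keep the number close to that of compound 1, with compound 3 the one carbamate that stays within the scatter of it. Compound 2 and compound 4 each give a limit rather than a number, so the step between them cannot be read and the oxan-4-yl and ethoxy groups cannot be ranked against each other: the limit of > 3.7 in this assay, at which 2 of the 4 values shown sit.

From the compounds shown here alone, how far past the limit compound 4 really lies remains open, and with it the full size of both readable steps. Also open, going by these compounds, is whether a longer chain in place of the ethoxy group, or a chain ending in an amine or a carboxylic acid, would stay at the limit in this assay or come back toward the number of compound 3.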